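Shortening the linker chain: expectation for compound 3

The source may report more compounds than this note shows. Statements on the series, on what has been measured and on what is new or still open speak of the compounds shown alone.

Of the compounds shown here, two sharing one core have been measured in an ADME assay on cells (Hepatocyte, Homo sapiens) for metabolic stability; a lower number here means slower removal, a higher number faster removal of the compound. Compound 1, `COc1nnc2ccc(N3CCC(c4ccc(N5CCC(N6CCN(C)C(=O)[C@H]6C)CC5)cc4)CC3)nn12`, gives 2.7 uL/min in this assay. Compound 2, `COc1nnc2ccc(N3CCC(c4ccc(OCCCCN5CCN(C)C(=O)[C@H]5C)cc4)CC3)nn12`, gives 12 uL/min in this assay, the highest of the two numbers, and its gap to compound 1 lies beyond the usual scatter. For the measured compounds named here, no pair of measured compounds differs in only one place, so no measured single step is available to guide the next change. Compound 3, `COc1nnc2ccc(N3CCC(c4ccc(OCCCN5CCN(C)C(=O)[C@H]5C)cc4)CC3)nn12`, is compound 2 with one alteration: a group of 9 heavy atoms (6 carbon, 2 nitrogen, 1 oxygen; one six-membered non-aromatic ring with 2 hetero atoms) in place of a group of 10 heavy atoms (7 carbon, 2 nitrogen, 1 oxygen; one six-membered non-aromatic ring with 2 hetero atoms), on a saturated chain carbon, three bonds along the chain from an oxygen on an aromatic ring The entering group keeps the same ring as the one it replaces and differs only in the saturated chain. In this assay the step is expected to be small and to remain within the scatter, with no clear direction: a 1.2-fold lower number from compound 2 to compound 3 (0.08 log units; within the scatter). Compound 3 is therefore estimated to give 10 uL/min in this assay, expected to fall between 5 uL/min and 20 uL/min.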

Compound 3, intrinsic clearance in a liver preparation (reported as CLH), per the amount of preparation that the assay uses in the Hepatocyte assay: 5.1 uL/min
The estimate for compound 3 lay 2.0-fold (0.29 log units) above the measured number; low and high end bracket the measured number.
By their numbers in the Hepatocyte assay, from the lowest: compounds 1 and 3 (each within the scatter of the next); then compound 2.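

For the compounds shown here, putting the group of 9 heavy atoms in place of the group of 10 heavy atoms, on a saturated chain carbon, three bonds along the chain from an oxygen on an aromatic ring, gives the first single-place step in the Hepatocyte assay: a 2.4-fold lower number from compound 2 to compound 3 (0.37 log units; beyond the scatter). In a physicochemical assay for lipophilicity, at pH 7.4 (on this read-out higher numbers stand for higher lipophilicity and lower numbers for lower lipophilicity), compound 2 gives 2.8 and compound 3 gives 2.4. The lower number for removal therefore comes with lower lipophilicity, which offers a possible cause for the step: the measured distribution coefficient of compound 2, 2.8, and of compound 3, 2.4, a number 0.40 log units lower (beyond the scatter)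

This single step cannot show whether lipophilicity or the length of the chain itself governs the removal. It also leaves open whether a still shorter chain, or a hydroxyl group on the chain, would lower the number further.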